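Swapping a Hydrogen for Fluorine on a Pendant Phenyl

This account rests on a few compounds, and the source may have more. Where it says the series, first, only, none or still open, it means among the compounds named here.

Measured so far:
- Compound 1 `CC1=C(c2ccc(O)cc2)C(c2ccc(OC[C@H](C)N3CC[C@@H](C)C3)cc2)Oc2cc(O)ccc21` gives 0.2 nM in a functional assay on MCF7 cells (Homo sapiens) for antiproliferative activity, read by CellTiter-Glo, with a stated time of 5 days; on this read-out lower numbers stand for stronger inhibition and higher numbers for weaker inhibition
- Compound 2 `CC1=C(c2ccccc2)C(c2ccc(OC[C@H](C)N3CC[C@@H](C)C3)cc2)Oc2ccc(O)cc21` gives 0.4 nM in this assay

Both compounds share the same core and the same amine-bearing side chain, and both were tested in this assay. Compound 2 shows the number that sits at the top of the two, yet the gap to compound 1 is within the usual scatter of repeated measurements, so the two cannot be separated on these data.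

Compound 3 `CC1=C(c2ccc(F)cc2)C(c2ccc(OC[C@H](C)N3CC[C@@H](C)C3)cc2)Oc2ccc(O)cc21` has not yet been measured. It differs from compound 2 in one place: fluoro in place of hydrogen on an aromatic carbon. Among the measured compounds shown here, no step of this kind between two measured compounds is available here, so nothing measured tells how such a change behaves. With only one heavy atom entering and nothing else altered, the expectation is a step from compound 2 to compound 3 in this assay of no change at the digits printed from compound 2 to compound 3 (within the scatter), which is no larger than the scatter itself, in no firm direction. Compound 3 is therefore estimated at 0.4 nM, within a range of 0.15 nM to 1.2 nM.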

Compound 3, half-maximal inhibitory concentration: 0.4 nM
Compound 3: middle estimate and measured number agree at the digits printed; measured number inside the range.
By their numbers in this assay, from the lowest: compounds 1, 2 and 3 (each within the scatter of the next).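

Swapping hydrogen for fluoro on the pendant ring, the change from phenyl to 4-fluorophenyl, gives no change at the digits printed from compound 2 to compound 3 (within the scatter) in this assay and supplies the first measured step in this set between two compounds that differ in one place. It shows that this spot, on an aromatic carbon para to a large group, can take a fluoro with no shift in the read-out that stands clear of the normal variation between repeat measurements. This single step describes one substituent at one position in one cell assay, so it sets no rule for other groups or for other places on the ring, and no measurement here accounts for the flat result.

Still open, on these data alone, is how this same position responds to groups other than fluoro, such as chloro, methoxy, trifluoromethyl, an amine or a carboxylic acid. The compounds shown also leave unanswered whether a fluoro on another carbon of this ring would behave in the same way, and whether a longer chain at this position would keep the number where it stands.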